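The compounds below may be only part of what the source reports. "The series", "measured", "known", "first", "only" and "open" are said of these compounds alone.

Measured so far:
- compound 1, `CCCCCCC(=O)OCc1ccc2oc(=O)c(C(=O)Oc3cccc(Br)c3)cc2c1`: 55.6%
- compound 2, `CC(=O)NCc1ccc2oc(=O)c(C(=O)Oc3cccc(F)c3)cc2c1`: 65.6%

Of the compounds shown here, two have been tested in a functional assay on HT-1080 cells (Homo sapiens), read by transwell migration, with a stated time of 24 h, tested at 1 uM; a higher number here means a weaker effect of the compound at the concentration tested, a lower number a stronger effect. Compound 1 gives 55.6% and compound 2 gives 65.6%. The two numbers sit within the usual scatter of each other, so they do not tell one compound apart from the other, and compound 2 stands where compound 1 stands as far as this read-out can show.

The next compound, compound 3 with the structure `CC(=O)NCc1ccc2oc(=O)c(C(=O)Oc3cccc(Br)c3)cc2c1`, keeps the whole of compound 2 except at one point: bromo in place of fluoro on an aromatic carbon. Within the data shown here, compound 1 also carries a bromo group on that ring, but it differs from compound 2 on the other side of the shared core as well, so no single-change step is available to guide the expectation.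

With nothing to lean on beyond the two values, the expected step in this assay from compound 2 to compound 3, a number 4.6 percentage points lower from compound 2 to compound 3 (within the scatter), is a small one, and it is estimated to stay within the scatter rather than run clearly in either direction. Compound 3 is therefore expected to give about 61%, with a range from 42% to 80%.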

Compound 3, a percentage reported as activity, at one concentration (the size of the read-out at that concentration, not a potency): 36.9%
Compound 3: middle estimate off by 24.1 percentage points, on the high side; the whole stated range lies above it.
By their numbers in this assay, from the lowest: compound 3; then compounds 1 and 2 (each within the scatter of the next).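

In this assay, among these compounds, swapping 3-fluorophenyl for 3-bromophenyl gives the first single-change step at this position (a number 28.7 percentage points lower from compound 2 to compound 3 (beyond the scatter)), which shows that exchanging this one halogen on the aromatic ring, with the rest of the molecule held fixed, moves the read-out toward a stronger effect. The other side of the shared core also matters once the 3-bromophenoxy group is held constant, since acetamido in place of (hexylcarbonyl)oxy gives a step of its own (a number 18.7 percentage points lower from compound 1 to compound 3 (beyond the scatter)), and compound 3 therefore has the strongest effect of the three at the concentration tested. Nothing measured here explains why either change has this effect.

Only fluoro and bromo are shown at this ring position, so it remains open what chloro, iodo, methoxy or a plain hydrogen would give there, and whether the read-out follows any order across such groups. Going by these compounds, on the other side of the core, it also remains open how a longer amide chain or an amine would compare with acetamido, and whether the effect of the bromo group carries over when (hexylcarbonyl)oxy takes the place of acetamido.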